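This account rests on a few compounds, and the source may have more. Where it says the series, first, only, none or still open, it means among the compounds named here.

Working notes on the series. In a functional assay on RAW264.7 cells (Mus musculus) for inhibition, read by Griess assay, with stated times of 2 h and 24 h (a lower number here means a stronger inhibitor, a higher number a weaker inhibitor), compound 1 `COc1ccc([C@@H]2CC(=O)c3c(O)cc(OCc4cn(Cc5ccc(Cl)cc5)nn4)cc3O2)cc1O` gives 17800 nM, compound 2 `COc1ccc([C@@H]2C/C(=N\O)c3c(O)cc(OCc4cn(Cc5ccccc5F)nn4)cc3O2)cc1O` gives 5710 nM and compound 3 `COc1ccc([C@@H]2CC(=O)c3c(O)cc(OCc4cn(Cc5cccc(C#N)c5)nn4)cc3O2)cc1O` gives 18000 nM. Compound 3 carries the highest number of the three; compound 1 sits within the scatter of it, while compound 2 gives a number beyond the scatter lower. The step to compound 4 `COc1ccc([C@@H]2CC(=O)c3c(O)cc(OCc4cn(Cc5cccc(C)c5)nn4)cc3O2)cc1O` is methyl in place of cyano on an aromatic carbon. Among the measured compounds shown here, the only step that bears on it is the earlier change of the group on the same aromatic ring, a 1.0-fold higher number from compound 1 to compound 3 (0.00 log units; within the scatter), which stayed within the scatter. On that basis no movement beyond the scatter is expected in this assay for compound 4, no change at the digits printed from compound 3 to compound 4 (within the scatter). Compound 4 is therefore estimated at 18000 nM, expected between 8000 nM and 40000 nM.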

Compound 4, half-maximal inhibitory concentration: 17400 nM
The estimate for compound 4 lay 1.0-fold (0.01 log units) above the measured number; the range from low to high includes it.
By their numbers in this assay, from the lowest: compound 2; then compounds 4, 1 and 3 (each within the scatter of the next).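

In this assay the aromatic carbon that carried cyano in compound 3 also takes methyl, which has no hydrogen-bond acceptor and no triple bond, with a 1.0-fold lower number from compound 3 to compound 4 (0.01 log units; within the scatter) and no shift beyond the scatter. The replacement of 4-chlorophenyl also stays within the scatter, with a 1.0-fold lower number from compound 1 to compound 4 (0.01 log units; within the scatter) as the step. No data on the reason for this flat response are available.

On these data alone, whether an amine or a carboxylic acid on this ring would leave the number unchanged remains open. So does whether the same tolerance holds on the core of compound 2.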